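The source may hold more compounds than are shown below. What is called first, only, known or untested is meant among the compounds shown, and "the series" means these compounds.

In a functional assay on the whole organism with Mus musculus as the target, with a stated time of 0.5 h (on this read-out higher numbers stand for an effect only at larger amounts of compound and lower numbers for an effect already at smaller amounts), compound 1 `O=C(CNc1ccc(F)cc1)Nc1nc2ccc(Cl)cc2s1` gives 100 mg/kg.
In this assay, compound 2 `Fc1ccc(/C=N/NC(=S)Nc2nc3ccc(Cl)cc3s2)cc1` gives 100 mg/kg.
In this assay, compound 3 `CC(C)(C)NCC(=O)Nc1nc2ccc(Cl)cc2s1` gives 100 mg/kg.

All three compounds share the same core, and on the numbers shown compound 3 stands level with compound 1 and compound 2 in this assay; none of the three is set apart from the others. Going by the values given here, only one measured step changes a single place: no change at the digits printed from compound 1 to compound 3 (within the scatter), tert-butyl in place of 4-fluorophenyl on an amine nitrogen, and it left the minimum effective dose where it was.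

Compound 4 `O=C(CN1CCCCC1)Nc1nc2ccc(Cl)cc2s1` is not yet measured. Its change from compound 3 is piperidin-1-yl in place of (tert-butyl)amino on a saturated chain carbon bound to a carbonyl carbon. Among the compounds with values here, the one measured step is the only guide, and it also altered the group attached to an amine nitrogen without moving the read-out. The change in compound 4 goes further, since the ring now closes over that nitrogen, but nothing measured points either way. The expectation is therefore a step of no change at the digits printed from compound 3 to compound 4 (within the scatter), that is, none beyond the scatter. For compound 4 the estimate in this assay is 100 mg/kg, with a range from 50 mg/kg to 200 mg/kg.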

Compound 4, minimum effective dose in the Mus musculus assay: 100 mg/kg
Beside the measured number, compound 4's estimate shows no gap at the digits printed; the range from low to high includes it.
By their numbers in the Mus musculus assay, from the lowest: compounds 1, 2, 3 and 4 (each within the scatter of the next).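

In the Mus musculus assay the new step shows no change at the digits printed from compound 3 to compound 4 (within the scatter) even though piperidin-1-yl, with 0 hydrogen-bond donors, replaces (tert-butyl)amino, which has 1. The earlier step at an amine nitrogen kept that nitrogen's hydrogen, so this pair adds that the read-out also stays level when the hydrogen-bond donor is gone and a ring closes over the nitrogen. In a physicochemical assay for lipophilicity, in phosphate buffer, measured as octanol-water partition (on this read-out lower numbers stand for lower lipophilicity and higher numbers for higher lipophilicity), compound 3 gives 3.02 and compound 4 gives 3.16 and these two values lie within the scatter of each other.

Nothing measured here offers a reason for the level result. Going by these compounds, with all four compounds at one dose, it stays open whether any other group on this saturated chain carbon, such as a morpholine ring, a carboxylic acid or a longer chain, would move the read-out at all.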